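Trimming a Pyrrolidine Ring to a Bare Amino Group

A few compounds are considered here, and "the series" means these few. Any claim that something is new, unique, unknown or untested is made for them only; others in the source may bear on it.

Measured compounds:
- compound 1 `Cn1c(N2CCCC2)c(C#N)c2c(N)ncnc21`: 1480 nM
- compound 2 `C[C@@H]1CCCN1c1c(C#N)c2c(N)nc(Nc3cn(C)nc3C(F)(F)F)nc2n1C`: 508 nM

Of the compounds shown here, two sharing one core have been tested in an assay on isolated protein for inhibition of Leucine-rich repeat serine/threonine-protein kinase 2 (Homo sapiens), read by TR-FRET and LanthaScreen, with stated times of 50 min and 30 min, in the presence of a further agent that is not named here; on this read-out higher numbers stand for weaker inhibition and lower numbers for stronger inhibition. Compound 1 shows the highest of the two numbers in this assay; its nearest neighbour is compound 2, whose number is lower and the gap lies beyond the scatter. Compound 2 carries several extra groups at once, so its value alone says nothing about any single change.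

Compound 3 `Cn1c(N)c(C#N)c2c(N)ncnc21` has not yet been measured. It differs from compound 1 in one place: amino in place of pyrrolidin-1-yl on an aromatic carbon. The pyrrolidin-1-yl group with its five heavy atoms leaves, and a single-atom amino group, which adds a hydrogen-bond donor, enters.

Among the compounds with values here, no measured pair here isolates this change, so the expected step rests on the two values alone. Compound 3 is expected to be somewhat weaker than compound 1 in this assay, a step of a 2.7-fold higher number from compound 1 to compound 3 (0.43 log units; beyond the scatter), since removing most of a substituent rarely leaves the number unchanged. The estimate for compound 3 is 4000 nM, within a range from 1000 nM to 15000 nM.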

Compound 3, half-maximal inhibitory concentration: 14400 nM
Compound 3: middle estimate off by 3.6-fold (0.56 log units), on the low side; low and high end bracket the measured number.
By their numbers in this assay, from the lowest: compound 2; then compound 1; then compound 3.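

In this assay, replacing pyrrolidin-1-yl with amino on this aromatic carbon gives a 9.7-fold higher number from compound 1 to compound 3 (0.99 log units; beyond the scatter), a step well beyond the usual scatter. Compounds 1 and 2 differ in several places at once, so they could not show this; the new pair shows that inhibition at this position depends on which group the carbon carries, and that the bare amino group is clearly the poorer of these two. Nothing in the data shown explains why the number rises.

This single step combines two changes, the loss of the five-membered ring with its carbons and the gain of a hydrogen-bond donor, so their separate contributions cannot be told apart. A dimethylamino group, which keeps carbons on the nitrogen without a ring or a donor, and a methylamino group, which keeps the donor and adds one carbon, would begin to pull these apart, while a piperidin-1-yl ring would test whether a larger ring than pyrrolidin-1-yl is tolerated at this position.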